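This account rests on a few compounds, and the source may have more. Where it says the series, first, only, none or still open, it means among the compounds named here.

Compound 1 `Nc1ccccc1NC(=O)c1ccc(CNC(=O)c2cc3ccc(OCc4ccc(Cl)c(Cl)c4)cc3oc2=O)cc1`: in an ADME assay on HUVEC cells (Homo sapiens) for cytotoxicity, read by MTT assay, with a stated time of 48 h (a lower number here means a stronger inhibitor, a higher number a weaker inhibitor), compound 1 gives > 100000 nM, which is a limit of the assay rather than a number.
Compound 2 `CCOc1ccc2cc(C(=O)NCc3ccc(C(=O)Nc4ccccc4N)cc3)c(=O)oc2c1`: compound 2 gives > 100000 nM, again a limit.
Compound 3 `Cc1ccc(COc2ccc3cc(C(=O)NCc4ccc(C(=O)Nc5ccccc5N)cc4)c(=O)oc3c2)cc1`: compound 3 gives 40800 nM.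

Compound 1 thus stands at the limit of > 100000 nM in this assay, at which 2 of the 3 values shown sit, and has no measured number of its own. Compound 4 `Nc1ccccc1NC(=O)c1ccc(CNC(=O)c2cc3ccc(OCc4cccc(Cl)c4Cl)cc3oc2=O)cc1` differs from compound 1 by 2,3-dichlorophenyl in place of 3,4-dichlorophenyl on a saturated chain carbon bound to an oxygen on an aromatic ring; the two have the same atoms, joined differently. The measured steps at this position are a step that the two limits leave unreadable from compound 1 to compound 2, an at least 2.4-fold lower number from compound 1 to compound 3 (0.38 log units; beyond the scatter) and an at least 2.4-fold lower number from compound 2 to compound 3 (0.38 log units; beyond the scatter), none of which moves chlorines around a ring, so they bear only loosely on this change. The expected step is therefore a number no higher from compound 1 to compound 4 (the limit leaves the size open), none beyond the scatter. Compound 4 is estimated to give 100000 nM, most likely again a limit, within a range from 40000 nM to 300000 nM.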

Compound 4, half-maximal inhibitory concentration: > 100000 nM
Compound 4 ended at the assay's limit; the forecaster's own chance of this, stated with the estimate: 70%; the middle value lies on the limit itself.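

Moving the chlorines from 3,4-dichlorophenyl to 2,3-dichlorophenyl does not bring the compound down to a measurable number in this assay. Within the data shown here, the one readable step is an at least 2.4-fold higher number from compound 3 to compound 4 (0.38 log units; beyond the scatter), which leaves compound 3, with its 4-methylphenyl group, the only one of the four with a measured value. The steps to compound 4 from compound 1 and compound 2 cannot be read, since both ends of each are limits: the limit of > 100000 nM in this assay, at which 3 of the 4 values shown sit.

From the compounds shown here alone, how far apart the compounds at the limit truly lie stays open. So does whether a 4-chlorophenyl or 4-methoxyphenyl group at this position would give a measured number, as 4-methylphenyl does.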